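The source may report more compounds than this note shows. Statements on the series, on what has been measured and on what is new or still open speak of the compounds shown alone.

Measured in an assay on cells for displacement of a labelled ligand from adenosine receptor A3 (Homo sapiens), read by scintillation counting and radioligand binding, with a stated time of 180 min, tested at 10 uM; a higher number here means more inhibition at the concentration tested (going by the name of the read-out), a lower number less inhibition:
compound 1 `CN1CCN(c2nc(-c3cccc(O)c3)nc3c2ncn3C)CC1` gives 63.8%.
compound 2 `CN1CCN(c2nc(-c3ccc(Cl)c(Cl)c3)nc3[nH]cnc23)CC1` gives only a limit, > 80%.

Compound 2 thus stands not at a number but at a limit, namely (the limit of > 80% in this assay, at which 1 of the 2 values shown sits). Compound 3 `CN1CCN(c2nc(-c3ccc(Cl)c(Cl)c3)nc3c2ncn3C)CC1` arises from compound 2 by methyl in place of hydrogen on an aromatic nitrogen. Among the measured compounds shown here, no measured pair here shows that change by itself; compound 1 carries the methyl on the same aromatic nitrogen but a different aryl group, so its value cannot be read as the effect of the methyl alone. No step beyond the usual scatter is expected in this assay, in either direction. Compound 3 is therefore estimated at 75%, with a range from 50% to 95%. That estimate means an expected step of a number at least 5 percentage points lower from compound 2 to compound 3 (that floor lies within the scatter).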

Compound 3, a percentage reported as inhibition, at one concentration (the size of the read-out at that concentration, not a potency): 35.3%
Beside the measured number, compound 3's estimate is 39.7 percentage points above it; measured number outside the range, below it.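

In this assay, methyl in place of hydrogen on an aromatic nitrogen can now be read with the 3,4-dichlorophenyl group held constant, and it gives a number at least 44.7 percentage points lower from compound 2 to compound 3 (beyond the scatter). Compound 2 stands at a limit, so this step is a bound rather than an exact size: the limit of > 80% in this assay, at which 1 of the 3 values shown sits. With the methyl kept on that nitrogen, 3,4-dichlorophenyl in place of 3-hydroxyphenyl on an aromatic carbon gives a number 28.5 percentage points lower from compound 1 to compound 3 (beyond the scatter).

The compounds shown leave open whether an ethyl group or a longer chain on that nitrogen would give a similar step, and how the 3-hydroxyphenyl group reads with hydrogen there.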